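Swapping an aryl group on the thiosemicarbazone of compound 1

The source may report more compounds than this note shows. Statements on the series, on what has been measured and on what is new or still open speak of the compounds shown alone.

Compound 1, `COc1ccc(/C=N/NC(=S)NC(C)(C)[C@H]2CC=C(C)CC2)cc1`: 21200 nM
Compound 2, `CC1=CC[C@H](C(C)(C)NC(=S)N/N=C/c2ccccc2[N+](=O)[O-])CC1`: 25800 nM

Of the compounds shown here, two have been measured in a functional assay on OVCAR-3 cells (Homo sapiens) for inhibition, read by sulforhodamine B assay, with a stated time of 48 h; on this read-out lower numbers stand for stronger inhibition of growth and higher numbers for weaker inhibition of growth. Compound 1 gives 21200 nM, the lower of the two numbers, and compound 2 gives 25800 nM; the two values sit within the scatter of each other, so no order between them can be read from these data.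

Compound 3, `CC1=CC[C@H](C(C)(C)NC(=S)N/N=C/c2ccc[nH]2)CC1`, has not been measured. Compared with compound 1 it differs in one place: 1H-pyrrol-2-yl in place of 4-methoxyphenyl on a carbon with a double bond to nitrogen. Going by the values given here, no step between two measured compounds that differ in a single place is available, so the size of this change cannot be calibrated from the data. In this assay a step from compound 1 to compound 3 of no more than modest size, in either direction and possibly not beyond the scatter, is expected. The value expected for compound 3 is 28000 nM, with a range from 10000 nM to 80000 nM, which amounts to an expected step of a 1.3-fold higher number from compound 1 to compound 3 (0.12 log units; within the scatter).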

Compound 3, concentration for total growth inhibition: > 100000 nM
Compound 3: a limit, no number; the forecaster's own chance of this, stated with the estimate: 25%; middle value at least 3.5-fold (0.55 log units) from the limit.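

Going by these compounds alone, for the first time, a change in one place at this position can be sized: in this assay, 1H-pyrrol-2-yl in place of 4-methoxyphenyl on a carbon with a double bond to nitrogen gives an at least 4.7-fold higher number from compound 1 to compound 3 (0.67 log units; beyond the scatter). Compound 3 gives > 100000 nM, which is a limit of the assay and not a number. The position is therefore not indifferent to the group it carries, and the size of the step rests on that limit: the limit of > 100000 nM in this assay, at which 1 of the 3 values shown sits.

This single step cannot separate the five-membered ring, its ring nitrogen and its hydrogen-bond donor from one another. The compounds shown also leave open how a furan-2-yl group or a 1-methylpyrrol-2-yl group would behave at this place.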